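The compounds below may be only part of what the source reports. "The series", "measured", "known", "first", "only" and "open" are said of these compounds alone.

Measured so far:
Compound 1, `CCCc1nc(-c2ccccc2)c(CNCCN2CCN(c3ccccc3Cl)CC2)o1`, gives 4370 nM in an assay on HEK293 cells for inhibition of Voltage-dependent T-type calcium channel subunit alpha-1G (Homo sapiens), read by patch clamp; on this read-out higher numbers stand for weaker inhibition and lower numbers for stronger inhibition.
Compound 2, `CCCc1nc(-c2ccccc2)c(CNCCCN2CCN(c3cccc(C(F)(F)F)c3)CC2)o1`, gives 650 nM in this assay.

Of these two numbers, compound 2 stands at the lower one; compound 1 lies higher, and the gap between them is beyond the usual scatter. Within the data shown here, compound 1 and compound 2 differ from one another in more than one place, so no single step connects them, and only their two values can be read.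

Compound 3, `CCCc1nc(-c2ccccc2)c(CNCCCN2CCN(c3ccccc3Cl)CC2)o1`, has not yet been measured in this assay. It differs from compound 2 in one place: 2-chlorophenyl in place of 3-(trifluoromethyl)phenyl on an amine nitrogen in a ring. The 2-chlorophenyl group that enters is also present in compound 1, whose value in this assay is the higher one. On that basis the estimate for compound 3 is a moderate rise in the number, a 2.5-fold higher number from compound 2 to compound 3 (0.39 log units; beyond the scatter), that is, somewhat weaker inhibition than compound 2. The expected value for compound 3 is 1600 nM, with a range from 500 nM to 5000 nM.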

Compound 3, half-maximal inhibitory concentration: 2800 nM
For compound 3 the middle estimate is 1.8-fold (0.24 log units) below the measured one; measured number inside the range.
By their numbers in this assay, from the lowest: compound 2; then compounds 3 and 1 (each within the scatter of the next).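

With everything else in the molecule unchanged, putting 2-chlorophenyl in place of 3-(trifluoromethyl)phenyl on the amine nitrogen in the ring gives, in this assay, a 4.3-fold higher number from compound 2 to compound 3 (0.63 log units; beyond the scatter) and so shows that the group on this nitrogen can move the number by itself, which the earlier pair, differing in more than one place, could not show. With 2-chlorophenyl on this nitrogen, compound 3 at 2800 nM and compound 1 at 4370 nM lie within the scatter of each other, and the two cannot be ordered. Nothing measured here bears on why the number rises with this change.

Whether the step follows the substituent itself or its place on the phenyl ring stays open, for 3-chlorophenyl, 2-(trifluoromethyl)phenyl and unsubstituted phenyl are not among the compounds shown. Also open, on these data alone, is whether 3-(trifluoromethyl)phenyl would give a similar number on the chain of compound 1.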